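Arylsulfonyl in Place of Acetyl on a Ring Nitrogen

A few compounds are considered here, and "the series" means these few. Any claim that something is new, unique, unknown or untested is made for them only; others in the source may bear on it.

Compound 1, `CCOC(=O)N1CCN(c2ccc(C(=O)c3cc4ccc(N(CC)CC)cc4o3)cc2)CC1`, in a functional assay on MCF7 cells (Homo sapiens) for cytotoxicity, read by MTT assay, with a stated time of 48 h (on this read-out lower numbers stand for stronger inhibition and higher numbers for weaker inhibition), reaches only a limit, > 40000 nM.
Compound 2, `CCN(CC)c1ccc2cc(C(=O)c3ccc(N4CCN(S(=O)(=O)c5ccc(Br)c(F)c5)CC4)cc3)oc2c1`, gives 2270 nM in this assay.
Compound 3, `CCN(CC)c1ccc2cc(C(=O)c3ccc(N4CCN(C(C)=O)CC4)cc3)oc2c1`, gives 16200 nM in this assay.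

Among the two numbers, compound 3 stands highest; its nearest neighbour is compound 2, reached by the step of a 7.1-fold higher number from compound 2 to compound 3 (0.85 log units; beyond the scatter). The value of compound 1 is a limit, not a number.

Compound 4, `CCN(CC)c1ccc2cc(C(=O)c3ccc(N4CCN(S(=O)(=O)c5ccc(C)cc5)CC4)cc3)oc2c1`, differs from compound 3 in one place: (4-methylphenyl)sulfonyl in place of acetyl on an amine nitrogen in a ring. Among the compounds with values here, two measured steps bear on this change. The step of a 7.1-fold higher number from compound 2 to compound 3 (0.85 log units; beyond the scatter) shows how much the number rises when an arylsulfonyl group on the ring nitrogen gives way to acetyl; the step of an at least 17-fold lower number from compound 1 to compound 2 (1.24 log units; beyond the scatter) shows an arylsulfonyl group lowering the number from a limit. Both point in the same direction for compound 4, and a step of roughly the same size as the reverse of the acetyl step is expected: a 5.4-fold lower number from compound 3 to compound 4 (0.73 log units; beyond the scatter). Compound 4 is therefore estimated at 3000 nM in this assay, with a likely range from 1000 nM to 10000 nM.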

Compound 4, half-maximal inhibitory concentration: > 40000 nM
Compound 4: no number, only a limit (the forecaster's own chance of this, stated with the estimate: 5%); middle value at least 13-fold (1.12 log units) from the limit.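

Compound 4 reaches only a limit in this assay, > 40000 nM. An arylsulfonyl group on this ring nitrogen therefore does not lower the number on its own: (4-methylphenyl)sulfonyl in place of acetyl gives an at least 2.4-fold higher number from compound 3 to compound 4 (0.39 log units; beyond the scatter), while 4-methylphenyl in place of 4-bromo-3-fluorophenyl on the sulfonyl sulfur gives an at least 17-fold higher number from compound 2 to compound 4 (1.24 log units; beyond the scatter), so among these compounds the low number of compound 2 goes with its particular aryl group and not with the sulfonyl link alone. The step joining compound 1 and compound 4 cannot be read, as both sit at the same limit: the limit of > 40000 nM in this assay, at which 2 of the 4 values shown sit.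

The compounds shown leave open whether the bromine, the fluorine or the two together go with the lower number of compound 2. They also leave open where a 4-bromophenyl, a 3-fluorophenyl or an unsubstituted phenyl on the sulfonyl sulfur would fall.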